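Amide in Place of Acid: Expected Exposure for Compound 4

The source may hold more compounds than are shown below. What is called first, only, known or untested is meant among the compounds shown, and "the series" means these compounds.

Measured compounds:
- compound 1 `C[C@H](c1ccc(-c2cc(Cl)ccc2-c2nc(=O)o[nH]2)cc1)N(CC1CC1)c1nc2c(C(=O)O)cccc2o1`: 1300 ng.h/mL
- compound 2 `CCCCN(c1nc2c(C(=O)O)cccc2o1)[C@H](C)c1ccc(-c2ccccc2-c2nnn[nH]2)cc1`: 429 ng.h/mL
- compound 3 `CCCCN(c1nc2c(NC(C)=O)cccc2o1)[C@H](C)c1ccc(-c2ccccc2-c2nnn[nH]2)cc1`: 41.6 ng.h/mL

The three measured compounds share a core and differ in the group attached to it. In an ADME assay on the whole organism (Macaca fascicularis) for pharmacokinetics, read by LC-MS, using cassette dosing, at a dose of 1 mg/kg by the oral route (on this read-out lower numbers stand for lower exposure and higher numbers for higher exposure at the dose given), compound 1 gives 1300 ng.h/mL, the highest of the three numbers. Compound 2 stands second with 429 ng.h/mL, and compound 3 is lowest with 41.6 ng.h/mL.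

The new compound, compound 4 `CCCCN(c1nc2c(C(=O)N(C)C)cccc2o1)[C@H](C)c1ccc(-c2ccccc2-c2nnn[nH]2)cc1`, is built from compound 2 by one change: dimethylamino in place of hydroxy on a carbonyl carbon. The carboxy group of compound 2 thus becomes a dimethylcarbamoyl group.

For the measured compounds named here, one measured step bears on this. When the carboxy group of compound 2 was replaced by acetamido, the result was a 10-fold lower number from compound 2 to compound 3 (1.01 log units; beyond the scatter). Compound 4 also loses the carboxy group, though to a different neutral group, so a step of similar direction is expected, a 7.2-fold lower number from compound 2 to compound 4 (0.85 log units; beyond the scatter), with real uncertainty about its size. Compound 4 is therefore estimated at 60 ng.h/mL, within a range from 15 ng.h/mL to 250 ng.h/mL.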

Compound 4, area under the concentration-time curve: 104 ng.h/mL
Compound 4: middle estimate off by 1.7-fold (0.24 log units), on the low side; measured number inside the range.
By their numbers in this assay, from the lowest: compound 3; then compound 4; then compound 2; then compound 1.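

In this assay, dimethylcarbamoyl in place of carboxy on this aromatic carbon gives a 4.1-fold lower number from compound 2 to compound 4 (0.62 log units; beyond the scatter) and so goes the same way as the acetamido group of compound 3, which makes two different replacements of the carboxy group that both lower the number. The replacements are not equal, since the change from acetamido to dimethylcarbamoyl gives a 2.5-fold higher number from compound 3 to compound 4 (0.40 log units; beyond the scatter) and the number therefore depends on which group takes the place of carboxy, not only on the loss of carboxy. No measurement shown here explains either step.

As far as these compounds go, what a plain carbamoyl group or a methyl ester would give on this carbon remains open. Also open, from the compounds shown here alone, is whether dimethylcarbamoyl in place of carboxy would lower the number to a similar extent on compound 1, which carries a cyclopropylmethyl group on its nitrogen.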